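A few compounds are considered here, and "the series" means these few. Any claim that something is new, unique, unknown or untested is made for them only; others in the source may bear on it.

Among the compounds with values here, in a functional assay on Caco-2 cells (Homo sapiens) for antiproliferative activity, read by MTT assay, with a stated time of 48 h (on this read-out higher numbers stand for weaker inhibition and lower numbers for stronger inhibition), the series so far varies only the group on a carbonyl carbon of a shared core. Compound 1 (`CCn1c(C(=O)N(CCC#N)CCC#N)ccc1C(CC)(CC)c1ccc(OCCC(O)(CC)CC)c(C)c1`) gives > 50000 nM, a limit and not a number. Compound 2 (`C#CC(C)OC(=O)c1ccc(C(CC)(CC)c2ccc(OCCC(O)(CC)CC)c(C)c2)n1CC`) gives > 50000 nM, again a limit. Compound 3 (`CCOc1ccc(NC(=O)c2ccc(C(CC)(CC)c3ccc(OCCC(O)(CC)CC)c(C)c3)n2CC)cc1`) gives > 50000 nM, also a limit, so its place in the series has no number attached. All the measurements so far end in the same way: the limit of > 50000 nM in this assay, at which 3 of the 3 values shown sit.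

Compound 4 (`CCOC(=O)CN(C)C(=O)c1ccc(C(CC)(CC)c2ccc(OCCC(O)(CC)CC)c(C)c2)n1CC`) carries ((ethoxycarbonyl)methyl)(methyl)amino in place of the (4-ethoxyphenyl)amino of compound 3, on the same carbonyl carbon: ((ethoxycarbonyl)methyl)(methyl)amino in place of (4-ethoxyphenyl)amino on a carbonyl carbon. The new group has no ring and no hydrogen-bond donor.

Within the data shown here, three measured steps bear on this change, all at that carbonyl carbon: a step that the two limits leave unreadable from compound 1 to compound 2, a step that the two limits leave unreadable from compound 1 to compound 3 and a step that the two limits leave unreadable from compound 2 to compound 3. Among the measured compounds shown here, none has a readable size, so they set no scale for a step and give no direction. What they do show is that three different groups at this place all end at the limit of > 50000 nM in this assay, at which 3 of the 3 values shown sit. On that basis, the most likely outcome in this assay is no change beyond the scatter, and probably another limit.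

The expected step is a number no higher from compound 3 to compound 4 (the limit leaves the size open). For compound 4 the estimated value is 50000 nM, with an expected range from 20000 nM to 80000 nM.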

Compound 4, half-maximal inhibitory concentration: 30300 nM
Estimate against measurement, compound 4: 1.7-fold (0.22 log units) above, within the range that was stated.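

In this assay, within the data shown here, compound 4 gives 30300 nM, a number and not a limit, so a group on this carbonyl carbon can bring the read-out into the measurable range, which the earlier compounds did not show. The steps are an at least 1.6-fold lower number from compound 3 to compound 4 (0.21 log units; that floor lies within the scatter), an at least 1.6-fold lower number from compound 2 to compound 4 (0.21 log units; that floor lies within the scatter) and an at least 1.6-fold lower number from compound 1 to compound 4 (0.21 log units; that floor lies within the scatter); each is only a floor, and because each floor lies within the scatter, none of them shows that the change goes beyond it. The ((ethoxycarbonyl)methyl)(methyl)amino group, which has no ring, is thus the only group here with a number, and the other compounds remain at a limit: the limit of > 50000 nM in this assay, at which 3 of the 4 values shown sit.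

Which part of this group matters remains open: the carboxylic acid in place of the ethyl ester, or a plain dimethylamino group on the same carbonyl carbon, would separate the ester from the methyl on the nitrogen. Going by these compounds, it is also open whether a longer chain between the nitrogen and the ester carbonyl would take the value further from the limit, or whether the value of compound 4 marks the most this position can give.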